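The source may hold more compounds than are shown below. What is called first, only, known or untested is meant among the compounds shown, and "the series" means these compounds.

The study starts from one shared core carried by three compounds. Compound 1 `CCOc1ccc(-n2nncc2CN2C(=O)C3(C(C#N)=C(N)Oc4c3c3nc5ccccc5nc3c3ccccc43)c3ccccc32)cc1` bears an ethoxy group on its pendant phenyl ring, and in a functional assay on MCF7 cells (Homo sapiens) for antiproliferative activity, read by MTT assay, with a stated time of 48 h (on this read-out higher numbers stand for weaker inhibition and lower numbers for stronger inhibition), compound 1 gives only a limit of > 50000 nM rather than a number. Compound 2 `CC(=O)Nc1ccc(-n2nncc2CN2C(=O)C3(C(C#N)=C(N)Oc4c3c3nc5ccccc5nc3c3ccccc43)c3ccccc32)cc1` carries acetamido in place of ethoxy on an aromatic carbon, and in this assay compound 2 also gives only a limit of > 50000 nM and no number. The step that the two limits leave unreadable from compound 1 to compound 2 therefore has no readable size, since both values sit at the limit of > 50000 nM in this assay, at which 2 of the 2 values shown sit, and compound 2 stands at that edge with nothing more known of it. Compound 3 `Cc1ccc(C)c(-n2nncc2CN2C(=O)C3(C(C#N)=C(N)Oc4c3c3nc5ccccc5nc3c3ccccc43)c3ccccc32)c1` is not yet measured; it differs from compound 2 by 2,5-dimethylphenyl in place of 4-acetamidophenyl on an aromatic nitrogen. Within the data shown here, the one measured step gives no direction to build on, so no step beyond the scatter is expected in this assay. Compound 3 is expected to give about 50000 nM, within 15000 nM to 150000 nM, an estimated step of a number no higher from compound 2 to compound 3 (the limit leaves the size open).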

Compound 3, half-maximal inhibitory concentration: > 50000 nM
Compound 3: only a limit was reported; the forecaster's own chance of this, stated with the estimate: 70%; the middle value lies on the limit itself.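

Compound 3 gives only a limit of > 50000 nM in this assay. Among these compounds, the steps to compound 3 from compound 1 and compound 2 therefore cannot be read, and no new step follows. The compounds shown leave open how strongly any of them inhibits, and whether any change on the shared core would give a number in this assay.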